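The compounds below may be only part of what the source reports. "The series", "measured", "known", "first", "only" and "open" are said of these compounds alone.

Measured so far in a functional assay (Homo sapiens) for inhibition of Nucleic Acid, tested at 100 uM; a higher number here means more inhibition at the concentration tested (going by the name of the read-out), a lower number less inhibition:

- compound 1, `[N-]=[N+]=Nc1nccc2c1ncn2[C@H]1C[C@H](O)[C@@H](CO)O1`: 4%
- compound 2, `CNc1nccc2c1ncn2C1O[C@H](CO)[C@@H](O)[C@H]1O`: 8%
- compound 3, `[N-]=[N+]=Nc1[nH]ccc2ncnc1-2`: 20%

Compound 3 gives the highest of the three numbers in this assay. Its nearest neighbour is compound 2, whose number lies lower by a margin beyond the scatter of repeated measurements, and compound 1 lies lower still, also beyond the scatter. Even so, all three numbers sit in the low range, so none of these compounds inhibits strongly at the concentration tested.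

The step to the unmeasured compound 4, `Sc1[nH]ccc2ncnc1-2`, keeps the core of compound 3 and changes one group: sulfanyl in place of azido on an aromatic carbon. The group that leaves is azido; the group that enters is sulfanyl, which brings one hydrogen-bond donor where azido brought none.

Among the compounds with values here, no measured pair shows this change, so its effect is unknown. With all numbers so low, the step from compound 3 to compound 4 is expected to stay within the scatter, perhaps drifting down, as a number 5 percentage points lower from compound 3 to compound 4 (within the scatter). Compound 4 is therefore estimated at 15% in this assay, within a range from 0% to 40%.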

Compound 4, a percentage reported as inhibition, at one concentration (the size of the read-out at that concentration, not a potency): 26%
Compound 4: middle estimate off by 11 percentage points, on the low side; the range from low to high includes it.
By their numbers in this assay, from the lowest: compounds 1 and 2 (each within the scatter of the next); then compounds 3 and 4 (each within the scatter of the next).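

In this assay, within the data shown here, replacing azido with sulfanyl on this aromatic carbon gives a number 6 percentage points higher from compound 3 to compound 4 (within the scatter), and this is the first single-place change that can be read. At this position, then, one heavy atom of sulfur can stand in for three nitrogen atoms, and a hydrogen-bond donor can enter where azido had none, without the number moving beyond the scatter. Nothing available accounts for this result.

From the compounds shown here alone, it remains open whether a different group on this same carbon, such as a chlorine atom or a carboxylic acid, would move the number beyond the scatter. Also open, going by these compounds, is whether the same swap would give a similar step on the core of compound 1.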